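Removing the Aminoethyl Chain: What to Expect for Compound 3

The compounds below may be only part of what the source reports. "The series", "measured", "known", "first", "only" and "open" are said of these compounds alone.

Compound 1 `NCCn1ncc2c(NCc3ccccc3[N+](=O)[O-])cc(C(F)(F)F)cc21` — 9%
Compound 2 `FC(F)(F)c1cc(NC[C@@H]2CCCCN2)c2cn[nH]c2c1` — 32%

Going by the values given here, in an assay for inhibition of Indoleamine 2,3-dioxygenase 1 (Homo sapiens), with stated times of 10 min and 60 min, tested at 10 uM (on this read-out higher numbers stand for a stronger effect at the one concentration tested and lower numbers for a weaker effect), compound 1 gives 9%, the lowest of the two numbers measured so far. Compound 2 gives 32%, a gap beyond the usual scatter. Compound 3 `O=[N+]([O-])c1ccccc1CNc1cc(C(F)(F)F)cc2[nH]ncc12` differs from compound 1 in a single place: hydrogen in place of 2-aminoethyl on an aromatic nitrogen. Among the compounds with values here, no measured pair here shows this kind of change, so its direction is open; only a small step, not beyond the scatter, is expected, namely a number 6 percentage points higher from compound 1 to compound 3 (within the scatter). Compound 3 is therefore estimated at 15%, with a range from 0% to 35%.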

Compound 3, a percentage reported as inhibition, at one concentration (the size of the read-out at that concentration, not a potency): 35%
Beside the measured number, compound 3's estimate is 20 percentage points below it; measured number inside the range.
By their numbers in this assay, from the lowest: compound 1; then compounds 2 and 3 (each within the scatter of the next).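

Putting hydrogen in place of 2-aminoethyl on the aromatic nitrogen gives, in this assay, a number 26 percentage points higher from compound 1 to compound 3 (beyond the scatter). This first pair at this position shows that what sits on that nitrogen matters to the read-out, and that of the two groups seen there, hydrogen goes with the higher number. No measurement here explains this step. Going by these compounds, it remains open whether the chain as a whole or its terminal amine accounts for the lower number; a methyl group or an ethyl group on this nitrogen would help to separate the two. This single pair also cannot show whether the step would hold with another group on the shared core.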